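Aryl to Propyl on the Thiourea Nitrogen

The source may hold more compounds than are shown below. What is called first, only, known or untested is meant among the compounds shown, and "the series" means these compounds.

Compound 1 `COc1cc2c(cc1OC)C(=O)C(CC1CCN(C(=S)Nc3ccccc3C)CC1)C2`, compound 2 `COc1cc2c(cc1OC)C(=O)C(CC1CCN(C(=S)Nc3ccccc3[N+](=O)[O-])CC1)C2` and compound 3 `COc1cc2c(cc1OC)C(=O)C(CC1CCN(C(=S)Nc3cccc([N+](=O)[O-])c3)CC1)C2` share one core and differ only in the group on the thiourea nitrogen. In a functional assay on the whole organism (strain Swiss albino) with Mus musculus as the target, in the maximal electroshock model, with a stated time of 0.5 h (on this read-out higher numbers stand for an effect only at larger amounts of compound and lower numbers for an effect already at smaller amounts), compound 1 gives 100 mg/kg, compound 2 gives 100 mg/kg, and compound 3 gives 300 mg/kg, the highest of the three numbers. The measured steps are modest: a 3.0-fold higher number from compound 1 to compound 3 (0.48 log units; beyond the scatter) and a 3.0-fold higher number from compound 2 to compound 3 (0.48 log units; beyond the scatter), whereas no change at the digits printed from compound 1 to compound 2 (within the scatter). Compound 4 `CCCNC(=S)N1CCC(CC2Cc3cc(OC)c(OC)cc3C2=O)CC1` arises from compound 3 by propyl in place of 3-nitrophenyl on an amide-type nitrogen. Going by the values given here, no measured step exchanges an aromatic group for a chain on this nitrogen, so the earlier steps show only the spread of the series and give no direction. Compound 4 is therefore expected to lie within that spread, with a 2.0-fold lower number from compound 3 to compound 4 (0.30 log units; within the scatter) as the expected step. The estimate for compound 4 is 150 mg/kg, with a range from 70 mg/kg to 400 mg/kg.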

Compound 4, minimum effective dose: 100 mg/kg
Compound 4: the middle estimate sits 1.5-fold (0.18 log units) above what was measured, and the stated range covers the measured number.
By their numbers in this assay, from the lowest: compounds 1, 2 and 4 (each within the scatter of the next); then compound 3.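

In this assay an aromatic group on this nitrogen proves not to be needed: propyl in place of 3-nitrophenyl gives a 3.0-fold lower number from compound 3 to compound 4 (0.48 log units; beyond the scatter) and leaves compound 4 level with the two other aryl compounds, with no change at the digits printed from compound 2 to compound 4 (within the scatter) and no change at the digits printed from compound 1 to compound 4 (within the scatter) as the printed steps. Of the four groups, only 3-nitrophenyl stands apart, and no measured evidence accounts for this. The compounds shown leave open whether a longer chain, a branched chain or a chain ending in an amine would hold this level, and whether an unsubstituted phenyl would match propyl.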